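Capping the phenol of compound 3 with a methyl

This account rests on a few compounds, and the source may have more. Where it says the series, first, only, none or still open, it means among the compounds named here.

For the measured compounds named here, compound 3 `COc1cc(/C=N/n2c(C)nc3c(cnn3-c3ccc(Cl)cc3)c2=O)ccc1O` gives 19800 nM in a functional assay on MCF7 cells (Homo sapiens) for cytotoxicity, read by colorimetric assay and sulforhodamine B assay, with a stated time of 48 h (a higher number here means a weaker inhibitor, a lower number a stronger inhibitor), the lowest of the three numbers so far, though its neighbours sit within the scatter: compound 1 `Cc1nc2c(cnn2-c2ccc(Cl)cc2)c(=O)n1/N=C/c1ccccc1` gives 23100 nM, and compound 2 `COc1ccc(/C=N/n2c(C)nc3c(cnn3-c3ccc(Cl)cc3)c2=O)cc1` gives 38600 nM. Across these three, there was a 1.7-fold higher number from compound 1 to compound 2 (0.22 log units; within the scatter), a 1.9-fold lower number from compound 2 to compound 3 (0.29 log units; within the scatter), and a 1.2-fold lower number from compound 1 to compound 3 (0.07 log units; within the scatter), so none of the changes on the aryl ring of the imine moved this assay beyond its noise.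

Compound 4 `COc1ccc(/C=N/n2c(C)nc3c(cnn3-c3ccc(Cl)cc3)c2=O)cc1OC` differs from compound 3 by methyl in place of hydrogen on an oxygen on an aromatic ring. The two earlier steps on the same ring, one adding a methoxy and one trading a 4-methoxyphenyl for a 4-hydroxy-3-methoxyphenyl, each stayed within the scatter, and the present change is of the same small kind. Compound 4 is therefore expected to show a 1.4-fold higher number from compound 3 to compound 4 (0.15 log units; within the scatter), with no step beyond the scatter in this assay. Compound 4 is estimated at 28000 nM, in a range from 12000 nM to 65000 nM.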

Compound 4, half-maximal inhibitory concentration: 25000 nM
Beside the measured number, compound 4's estimate is 1.1-fold (0.05 log units) above it; low and high end bracket the measured number.
By their numbers in this assay, from the lowest: compounds 3, 1, 4 and 2 (each within the scatter of the next).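

Replacing hydrogen with methyl on the oxygen in this assay gives a 1.3-fold higher number from compound 3 to compound 4 (0.10 log units; within the scatter) and so shows that, at this position, the hydroxy of compound 3 can be exchanged for a methoxy without a step beyond the scatter. The other two readings agree, with a 1.5-fold lower number from compound 2 to compound 4 (0.19 log units; within the scatter) when the second methoxy is added and a 1.1-fold higher number from compound 1 to compound 4 (0.03 log units; within the scatter) when 3,4-dimethoxyphenyl takes the place of phenyl, so this ring now has a capped and an uncapped oxygen pattern that cannot be told apart in this assay. No measurement is available that bears on the reason for this result.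

The compounds shown leave open whether an amine or a carboxylic acid on this ring would give a step beyond the scatter. They also leave open whether a longer chain in place of the methyl on this oxygen would do so.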